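Methyl in place of bromo: a small step expected again

The source may hold more compounds than are shown below. What is called first, only, known or untested is meant among the compounds shown, and "the series" means these compounds.

Three compounds have so far been measured in a functional assay on A549 cells (Homo sapiens) for antiproliferative activity, read by MTT assay, with a stated time of 48 h; a higher number here means a weaker inhibitor, a lower number a stronger inhibitor:

Compound 1, `Cc1ccc(-c2cc(NC(=O)/C=C/c3ccc(Cl)cc3)n[nH]2)cc1`, gives 1490 nM.
Compound 2, `O=C(/C=C/c1ccc(Br)cc1)Nc1cc(-c2ccccc2)[nH]n1`, gives 1460 nM.
Compound 3, `O=C(/C=C/c1ccc(Cl)cc1)Nc1cc(-c2ccc(Br)cc2)[nH]n1`, gives 1210 nM.

All three numbers lie close together. Compound 2 sits next to compound 1, and the gap between them is within the usual scatter, as is the gap between compound 2 and compound 3; no order among the three can be read from these values. The difference between the cores of compound 2 and compound 3 is not broken down here.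

Compound 3 and compound 1 differ in one place: methyl in place of bromo on an aromatic carbon. That change gave a 1.2-fold higher number from compound 3 to compound 1 (0.09 log units; within the scatter), a step that does not rise above the scatter of repeated measurements.

The unmeasured compound 4, `Cc1ccc(/C=C/C(=O)Nc2cc(-c3ccccc3)[nH]n2)cc1`, is related to compound 2 by the same change: methyl in place of bromo on an aromatic carbon. The place is described in the same words in both pairs, so this is the same change made on a different core.

Going by the values given here, since the one measured instance of this change, a 1.2-fold higher number from compound 3 to compound 1 (0.09 log units; within the scatter), stayed within the scatter, a step of similar size, a 1.2-fold higher number from compound 2 to compound 4 (0.07 log units; within the scatter), is expected from compound 2 to compound 4 in this assay. On that basis compound 4 is estimated at 1700 nM, with a likely range from 850 nM to 3400 nM.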

Compound 4, half-maximal inhibitory concentration: 1770 nM
Compound 4: the middle estimate sits 1.0-fold (0.02 log units) below what was measured; low and high end bracket the measured number.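

In this assay, methyl in place of bromo gave a 1.2-fold higher number from compound 2 to compound 4 (0.08 log units; within the scatter), and this step sits close to the one seen earlier on the other core: the same change on two cores in this assay, a 1.2-fold higher number (0.09 log units; within the scatter) from compound 3 to compound 1 and a 1.2-fold higher number (0.08 log units; within the scatter) from compound 2 to compound 4, 1.0-fold (0.01 log units) apart, within the scatter of two such steps

In these two pairs, then, the change carried from one core to the other without any sign that the core alters its outcome, and neither step rises above the scatter of repeated measurements. This does not show that swapping bromo for methyl has a real effect on the number in either core, nor that the two steps share a cause, and two pairs are too few to support a rule for other cores in the series or for other assays.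

The compounds shown have only bromo, chloro or methyl as a group on their six-membered aromatic rings, so it remains open whether an amine, a carboxylic acid or a methoxy group in the same place would produce a step beyond the scatter. On these data alone, it is also open whether any change at this place can move the number far from the narrow band that these four compounds occupy.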